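A few compounds are considered here, and "the series" means these few. Any claim that something is new, unique, unknown or untested is made for them only; others in the source may bear on it.

Measured compounds:
compound 1, `CN(C)CCCCCSC1=Nc2ccccc2C(CC(=O)NCc2ccc(F)cc2)N1c1ccc(-c2ccccc2)cc1`, 31%
compound 2, `CN(C)CCCCCSC1=Nc2ccccc2C(CC(=O)NCc2ccccc2)N1c1ccc(-c2ccc(F)cc2)cc1`, 97.6%
compound 3, `O=C(CC1c2ccccc2N=C(SCCCCCN2CCCC2)N1c1ccccc1)NCc1ccc(F)cc1`, 60.1%

These three compounds share one core and were tested in an assay on cells for inhibition of Voltage-dependent T-type calcium channel subunit alpha-1G (Homo sapiens), read by patch clamp, tested at 10 uM; on this read-out higher numbers stand for more inhibition at the one concentration tested (going by the name of the read-out) and lower numbers for less inhibition. Compound 2 gives 97.6%, the highest of the three numbers. The nearest to it is compound 3, with 60.1%, a gap beyond the usual scatter; the furthest is compound 1, with 31%, also beyond the scatter. Compound 2 therefore stands alone at the top of this small set.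

Compound 4, `CN(C)CCCCCSC1=Nc2ccccc2C(CC(=O)NCc2ccccc2)N1c1ccccc1`, has not yet been measured in this assay. It differs from compound 2 in one place: hydrogen in place of 4-fluorophenyl on an aromatic carbon. Nothing else in the molecule changes.

Going by the values given here, no pair of measured compounds differs in exactly this way, so no measured step can be carried over. The clearest hint comes from compound 3, which also carries a plain ring at the same place and reaches 60.1%, well below compound 2. On that basis the expected step from compound 2 to compound 4 in this assay is a decrease beyond the scatter, estimated as a number 42.6 percentage points lower from compound 2 to compound 4 (beyond the scatter). Compound 4 is therefore expected to give about 55%, within a range of 25% to 85%.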

Compound 4, a percentage reported as inhibition, at one concentration (the size of the read-out at that concentration, not a potency): 46.5%
For compound 4 the middle estimate is 8.5 percentage points above the measured one; low and high end bracket the measured number.
By their numbers in this assay, from the lowest: compound 1; then compound 4; then compound 3; then compound 2.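

Going by these compounds alone, the pair of compound 2 and compound 4 gives the first direct reading of this position: in this assay, putting hydrogen in place of the 4-fluorophenyl on an aromatic carbon, para to a large group, changes nothing else in the molecule and gives a number 51.1 percentage points lower from compound 2 to compound 4 (beyond the scatter). The 4-fluorophenyl at this place therefore counts for much of the inhibition seen at the one concentration tested, yet it is not required for all of it, since compound 4 still gives 46.5%. The data shown offer no independent measurement that could explain why the number falls.

This single change removes a whole ring and its fluorine together, so the compounds shown cannot separate what the ring contributes from what the fluorine contributes. Also open, on these data alone, is whether a chlorine atom, a methyl group or a pyridine ring at the same place would keep the inhibition close to that of compound 2 or leave it closer to that of compound 4.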